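From 4-chlorophenyl to 4-nitrophenyl: an open estimate

This account rests on a few compounds, and the source may have more. Where it says the series, first, only, none or still open, it means among the compounds named here.

The compounds measured in a functional assay on MCF7 cells (Homo sapiens) for cytotoxicity, read by MTT assay, with a stated time of 48 h (a higher number here means a weaker inhibitor, a lower number a stronger inhibitor), are these:

Compound 1 `COc1cc(-n2c(-c3ccccc3)cn(C(C)=O)c2=O)cc(OC)c1OC` gives > 50000 nM as a limit of the assay, not a number
Compound 2 `COc1cc(-n2c(-c3ccc(Br)cc3)cn(C(C)=O)c2=O)cc(OC)c1OC` gives 10600 nM as its value
Compound 3 `COc1cc(-n2c(-c3ccc(Cl)cc3)cn(C(C)=O)c2=O)cc(OC)c1OC` has "not determined" (no result reported) as its entry, with no result reported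

Compound 3 therefore offers no number from which to start. Compound 4 `COc1cc(-n2c(-c3ccc([N+](=O)[O-])cc3)cn(C(C)=O)c2=O)cc(OC)c1OC` differs from it by nitro in place of chloro on an aromatic carbon, para to a large group: nitro in place of chloro on an aromatic carbon is the full count.

For the measured compounds named here, only one measured step bears on this, and only indirectly: an at least 4.7-fold lower number from compound 1 to compound 2 (0.67 log units; beyond the scatter) is bromo in place of hydrogen on an aromatic carbon. Neither chloro nor nitro has a measured value, so no size or direction of step from compound 3 can be expected in this assay. Going by the values given here, the best anchor is compound 2 at 10600 nM as the only true number. A report of only a limit, as with compound 1, remains possible. Compound 4 is expected at about 14000 nM as an estimate, with an estimated range from 4000 nM to 50000 nM as its ends.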

Compound 4, half-maximal inhibitory concentration: > 50000 nM
Compound 4 ended at the assay's limit (the forecaster's own chance of this, stated with the estimate: 30%); middle value at least 3.5-fold (0.55 log units) away from the limit.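

At this place on the aromatic ring, para to a large group, the series now has a step upward in this assay: an at least 4.7-fold higher number from compound 2 to compound 4 (0.67 log units; beyond the scatter). The lower number seen with bromo therefore does not extend to nitro, and among the compounds with a reported result, only compound 2 has a true value rather than a limit. Compound 1 and compound 4 both stand at a limit of the assay, not at a number, so the step between them cannot be read: the limit of > 50000 nM in this assay, at which 2 of the 4 values shown sit.

With no result for compound 3, the compounds shown do not tell whether chloro behaves more like bromo or like nitro here. Going by these compounds, what an amine or a carboxylic acid would give at this place, and how far above the limit compound 1 and compound 4 lie, also remains open.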